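Clearance in Rats: The Step to Compound 4

This account rests on a few compounds, and the source may have more. Where it says the series, first, only, none or still open, it means among the compounds named here.

Measured so far in an ADME assay on the whole organism (strain Sprague-Dawley) for pharmacokinetics, with Rattus norvegicus as the target, at a dose of 1 mg/kg by the intravenous route; on this read-out higher numbers stand for fast clearance and lower numbers for slow clearance:
- compound 1 (`CCc1nn2c(C)cc(C)nc2c1Cc1ccc(/C=C/CN2CCNCC2=O)cc1`) gives "not determined" (no result reported)
- compound 2 (`CCc1nn2c(C)cc(C)nc2c1Cc1ccc(CCC(O)C2CCNCC2)cc1`) gives 31 mL/min/kg
- compound 3 (`CCc1nn2c(C)cc(C)nc2c1Cc1ccc(-c2nnc(N3CCNCC3)o2)cc1`) gives "not determined" (no result reported)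

Compound 1 therefore has no single number to stand on in this assay, and compound 3 is in the same position. Only compound 2 supplies a measured clearance so far.

The next compound is compound 4 (`CCc1nn2c(C)cc(C)nc2c1Cc1ccc(CCCC2(O)CCNCC2)cc1`), which has not yet been measured. Its structural change from compound 1 is 3-(4-hydroxypiperidin-4-yl)propyl in place of 3-(2-oxopiperazin-1-yl)prop-1-en-1-yl on an aromatic carbon, which places 3-(4-hydroxypiperidin-4-yl)propyl on the aromatic carbon that held 3-(2-oxopiperazin-1-yl)prop-1-en-1-yl.

Among the compounds with values here, no measured step shows what this exchange does, so neither the size nor the direction of a change from compound 1 can be stated. The expectation rests on compound 2 (31 mL/min/kg) alone, and compound 4 is expected to differ from that value by no more than the usual scatter. For compound 4 the estimated clearance is 30 mL/min/kg, with an expected range from 14 mL/min/kg to 60 mL/min/kg.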

Compound 4, clearance: 49 mL/min/kg
For compound 4 the middle estimate is 1.6-fold (0.21 log units) below the measured one; measured number inside the range.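

In this assay, the exchange of hydroxy(piperidin-4-yl)methyl for (4-hydroxypiperidin-4-yl)methyl on a saturated chain carbon, two bonds along the chain from an aromatic carbon, gives a 1.6-fold higher number from compound 2 to compound 4 (0.20 log units; within the scatter). Within the data shown here, this is the first step that can be read at this position, and it shows that these two groups cannot be told apart on clearance in this assay. The compounds shown offer no measured reason for either value.

As far as these compounds go, compound 1 and compound 3 have no single number, so steps from them cannot be read, and the effect of replacing 3-(2-oxopiperazin-1-yl)prop-1-en-1-yl remains unknown. From the compounds shown here alone, it also remains open whether a longer chain, or a carboxylic acid in place of the hydroxy group, would take clearance beyond the usual scatter.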